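This account rests on a few compounds, and the source may have more. Where it says the series, first, only, none or still open, it means among the compounds named here.

Of the compounds shown here, three sharing one core have been measured in a functional assay on M21 cells (Homo sapiens) for antiproliferative activity, read by sulforhodamine B assay, with a stated time of 48 h; a lower number here means a stronger inhibitor, a higher number a weaker inhibitor. Compound 1 `CC(C)(C)C(=O)Nc1ccc(S(=O)(=O)Oc2ccccc2I)cc1` gives 8300 nM, compound 2 `O=C(CCCl)Nc1ccc(S(=O)(=O)Oc2ccccc2I)cc1` gives 12000 nM, and compound 3 `CCCNC(=O)Nc1ccc(S(=O)(=O)Oc2ccccc2I)cc1` gives 5400 nM, the lowest of the three numbers. Compound 3 stands a 1.5-fold lower number from compound 1 to compound 3 (0.19 log units; within the scatter) and a 2.2-fold lower number from compound 2 to compound 3 (0.35 log units; beyond the scatter). Compound 4 `O=C(NCCCCl)Nc1ccc(S(=O)(=O)Oc2ccccc2I)cc1` differs from compound 3 by chloro in place of hydrogen on a saturated chain carbon, three bonds along the chain from an amide-type nitrogen. Among the measured compounds shown here, no measured step makes this same change; the nearest is a 1.4-fold higher number from compound 1 to compound 2 (0.16 log units; within the scatter), which also brings a chlorine onto a chain, though there the chain replaces a tert-butyl at the same time. On that slender basis the change from compound 3 to compound 4 is expected to remain within the scatter, a 1.1-fold higher number from compound 3 to compound 4 (0.05 log units; within the scatter). Compound 4 is therefore estimated at 6000 nM, with a range from 2500 nM to 14000 nM.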

Compound 4, half-maximal inhibitory concentration: 4600 nM
Estimate against measurement, compound 4: 1.3-fold (0.12 log units) above; measured number inside the range.
By their numbers in this assay, from the lowest: compounds 4, 3, 1 and 2 (each within the scatter of the next, the first and the last beyond it).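

Chloro in place of hydrogen on a saturated chain carbon, three bonds along the chain from an amide-type nitrogen, can now be read directly in this assay (a 1.2-fold lower number from compound 3 to compound 4 (0.07 log units; within the scatter)), and this single change stays within the scatter. The (3-chloropropyl)amino group stands beyond the scatter against 2-chloroethyl (a 2.6-fold lower number from compound 2 to compound 4 (0.42 log units; beyond the scatter)) but within it against tert-butyl (a 1.8-fold lower number from compound 1 to compound 4 (0.26 log units; within the scatter)). Nothing available explains these numbers. From the compounds shown here alone, whether bromo, hydroxyl or an amine would behave like chloro on this carbon remains open, as does the effect of a longer chain in place of propyl.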